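A few compounds are considered here, and "the series" means these few. Any claim that something is new, unique, unknown or untested is made for them only; others in the source may bear on it.

Measured compounds:
- compound 1, `COCC(C(=O)N1CCN(c2cccc(C(F)(F)F)c2)CC1)N1C(=O)CCC1=O`: 100%
- compound 2, `CCC(C(=O)N1CCN(c2cccc(OC)c2)CC1)N1C(=O)CCC1=O`: 0%
- compound 3, `CCC(C(=O)N1CCN(c2ccccc2F)CC1)N1C(=O)CCC1=O`: 0%

All three compounds share a core and were tested in a functional assay on the whole organism (strain Swiss) with Mus musculus as the target, in the maximal electroshock model, with a stated time of 2 h, at a dose of 300 mg/kg by the intraperitoneal route; a lower number here means a weaker effect, a higher number a stronger effect of the compound at the dose given. Compound 2 stands at the bottom of the three numbers shown: in this assay compound 2 gives 0%, level with compound 3, which gives 0%. Compound 1, the only one far from these two, gives 100%, a much higher number.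

The unmeasured compound 4, `CCC(C(=O)N1CCN(c2cccc(C(F)(F)F)c2)CC1)N1C(=O)CCC1=O`, differs from compound 2 in one place: trifluoromethyl in place of methoxy on an aromatic carbon. Going by the values given here, only one measured step touches this region of the molecule, the change from compound 2 to compound 3, and it gave no change at the digits printed from compound 2 to compound 3 (within the scatter). That step swapped in a different group at a different place on the ring, so it does not test the trifluoromethyl itself. Compound 1 carries the same trifluoromethyl as compound 4 but also differs from compound 4 in its side chain, so its high value cannot be read as a direct guide. The expectation for compound 4 is therefore uncertain, and a step from compound 2 of a number 50 percentage points higher from compound 2 to compound 4 (beyond the scatter) is estimated. Compound 4 is expected to give about 50% in this assay, within a range of 0% to 100%.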

Compound 4, a percentage reported as activity, at one dose (the size of the read-out at that dose, not a potency): 50%
Compound 4: middle estimate and measured number agree at the digits printed; the range from low to high includes it.
By their numbers in this assay, from the lowest: compounds 2 and 3 (each within the scatter of the next); then compound 4; then compound 1.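

In this assay, trifluoromethyl in place of methoxy on the aromatic carbon gives a number 50 percentage points higher from compound 2 to compound 4 (beyond the scatter), so the group at this place on the ring can move the read-out, whereas the earlier ring change gave no change at the digits printed from compound 2 to compound 3 (within the scatter). The trifluoromethyl group does not settle the number alone: with it held fixed, methyl in place of methoxy on the saturated chain carbon gives a number 50 percentage points lower from compound 1 to compound 4 (beyond the scatter), which shows that the side chain counts as well. No measurement shown here explains either large step.

The compounds shown leave open whether trifluoromethyl is special at this ring carbon or whether a chlorine atom, a nitrile or an ethoxy group there would also raise the number, and one step cannot show how far such a trend would reach. As far as these compounds go, on the chain carbon, it remains open how a hydroxyl group or a longer chain such as ethoxymethyl would compare with the methoxy and methyl compared here, and whether the two regions act independently.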